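The source may hold more compounds than are shown below. What is called first, only, known or untested is meant among the compounds shown, and "the series" means these compounds.

Series notes. Two compounds have numbers in a functional assay on HL-60 cells (Homo sapiens), with a stated time of 2 days (on this read-out lower numbers stand for stronger inhibition and higher numbers for weaker inhibition), so far. Compound 1 `C[C@@H](NC(=O)c1[nH]cnc1C(=O)Nc1ccc(Cl)c(Cl)c1)c1ccccc1` gives 8800 nM in this assay. Compound 2 `COC(=O)[C@H](NC(=O)c1[nH]cnc1C(=O)Nc1ccc(Cl)c(Cl)c1)c1ccccc1` gives 17300 nM in this assay. Of the two numbers, compound 2 stands at the upper end, but its gap to compound 1 lies within the usual scatter, so no difference between the two can be claimed from these data.

Compound 3 `COC(=O)[C@@H](NC(=O)c1[nH]cnc1C(=O)Nc1ccc(Cl)c(Cl)c1)c1ccccc1` is not yet measured. Against compound 2 the change is the two compounds have the same atoms and bonds and differ only in configuration as drawn: 1 of 1 stereo elements differ; a stereocentre at a saturated chain carbon is drawn R in compound 2 and S in compound 3; nothing else moves. Among the measured compounds shown here, no step between measured compounds is available, so there is no basis for a direction. The working expectation for the step from compound 2 to compound 3 is none beyond the scatter, a 1.2-fold lower number from compound 2 to compound 3 (0.06 log units; within the scatter), with the range kept wide because a single inverted stereocentre carries no reference point in this set. Compound 3 is estimated at 15000 nM in this assay, within a range from 3000 nM to 60000 nM.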

Compound 3, half-maximal inhibitory concentration: 13200 nM
Beside the measured number, compound 3's estimate is 1.1-fold (0.06 log units) above it; low and high end bracket the measured number.
By their numbers in this assay, from the lowest: compounds 1, 3 and 2 (each within the scatter of the next).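

In this assay, the saturated chain carbon bearing methoxycarbonyl now has both drawn configurations on record, and the comparison rests on stereochemistry alone: the fact that compounds 2 and 3 differ only in the configuration as drawn. The inversion gives a 1.3-fold lower number from compound 2 to compound 3 (0.12 log units; within the scatter), so the R and S forms cannot be told apart at this position on this read-out. Methoxycarbonyl in place of methyl on that carbon can now also be read as a change in one place, and it gives a 1.5-fold higher number from compound 1 to compound 3 (0.18 log units; within the scatter), so no difference can be claimed for this exchange either.

Still open, on these data alone, is whether a carboxylic acid, a primary amide or a longer chain in place of methoxycarbonyl on this carbon would shift the number beyond the scatter. Also open, as far as these compounds go, is whether configuration at this carbon would count with a different group there.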